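A few compounds are considered here, and "the series" means these few. Any claim that something is new, unique, unknown or untested is made for them only; others in the source may bear on it.

Values so far in a functional assay on Caco-2 cells (Homo sapiens) for inhibition, read by MTT assay, with a stated time of 48 h (on this read-out higher numbers stand for weaker inhibition and lower numbers for stronger inhibition), are these:

- compound 1 `Fc1ccc(/C=N/Nc2nc(-c3ccc(C(F)(F)F)cc3)cs2)cc1F` gives 14600 nM
- compound 2 `COc1cc(/C=N/Nc2nc(-c3ccccc3)cs2)c(Br)c(Br)c1OC` gives 26500 nM

These two numbers lie within the usual scatter of each other, so compound 1 cannot be ranked against compound 2 on this evidence. Compound 3 `Fc1ccc(/C=N/Nc2nc(-c3ccc(Br)cc3)cs2)cc1F` keeps the core of compound 1 and differs in one place. It has bromo in place of trifluoromethyl on an aromatic carbon, para to a large group (bromo in place of trifluoromethyl on an aromatic carbon). For the measured compounds named here, no measured pair shows what this swap does, so the data point in neither direction. In this assay the expectation is therefore no step beyond the scatter. The step of a 1.0-fold lower number from compound 1 to compound 3 (0.02 log units; within the scatter) is expected to be small. Compound 3 is estimated at 14000 nM within an expected range from 5000 nM to 40000 nM on this read-out.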

Compound 3, half-maximal inhibitory concentration: 43900 nM
For compound 3 the middle estimate is 3.1-fold (0.50 log units) below the measured one, and the stated range ends below it.
By their numbers in this assay, from the lowest: compounds 1, 2 and 3 (each within the scatter of the next, the first and the last beyond it).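

For the compounds shown here, this is the first pair in this assay that differs in only one place, so it isolates a single change. Bromo in place of trifluoromethyl, on an aromatic carbon para to a large group, gives a 3.0-fold higher number from compound 1 to compound 3 (0.48 log units; beyond the scatter), a modest step toward weaker inhibition, which shows that this position responds to the group it carries, with trifluoromethyl the better of these two. Nothing measured here on either group accounts for the step.

On these data alone, it remains open how other groups at this position would compare, such as a nitrile, an amine or a carboxylic acid, or a plain hydrogen with no substituent at all. A single pair also cannot show whether the same swap would give a similar step on a different core.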